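Bromo to tert-butoxy: working notes on the series

A few compounds are considered here, and "the series" means these few. Any claim that something is new, unique, unknown or untested is made for them only; others in the source may bear on it.

Values in a functional assay on HepG2 cells (Homo sapiens) for inhibition, read by MTT assay, with a stated time of 72 h; on this read-out higher numbers stand for weaker inhibition and lower numbers for stronger inhibition:
- compound 1 `CC(C)(C)Oc1ccc(-c2nnc(SCCCN3CCN(c4nc5ccccc5o4)CC3)o2)cc1` gives 121000 nM
- compound 2 `Clc1ccc(-c2nnc(SCCCN3CCN(c4nc5ccccc5s4)CC3)o2)cc1` gives 87700 nM
- compound 3 `Brc1ccc(-c2nnc(SCCCN3CCN(c4nc5ccccc5s4)CC3)o2)cc1` gives 103000 nM

Compound 3 lies within the scatter of both other compounds, so the three numbers form a single group with no order among them.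

The next compound is compound 4 `CC(C)(C)Oc1ccc(-c2nnc(SCCCN3CCN(c4nc5ccccc5s4)CC3)o2)cc1`, which differs from compound 3 as follows: tert-butoxy in place of bromo on an aromatic carbon (tert-butoxy in place of bromo on an aromatic carbon, para to a large group).

Among the compounds with values here, only one measured step bears directly on this place: a 1.2-fold higher number from compound 2 to compound 3 (0.07 log units; within the scatter) (bromo in place of chloro on an aromatic carbon). Within the data shown here, that step stays within the scatter, but it says little on its own about tert-butoxy, which no step between measured compounds introduces. Compound 1 does carry tert-butoxy, on a core of its own, and gives 121000 nM in this assay, which falls in the same group.

On these two points, no step beyond the scatter is expected in this assay, and neither direction is favoured. The expected step is small (a 1.0-fold higher number from compound 3 to compound 4 (0.01 log units; within the scatter)) and is estimated to stay within the scatter. For compound 4 the estimated value is 105000 nM, with an expected range from 60000 nM to 180000 nM.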

Compound 4, half-maximal inhibitory concentration: 202000 nM
Compound 4: middle estimate off by 1.9-fold (0.28 log units), on the low side; measured number outside the range, above it.
By their numbers in this assay, from the lowest: compounds 2, 3, 1 and 4 (each within the scatter of the next, the first and the last beyond it).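

Against bromo, tert-butoxy on this aromatic carbon, para to a large group, gives a 2.0-fold higher number from compound 3 to compound 4 (0.29 log units; within the scatter) in this assay and so stays inside the usual variation, while against chloro the same group gives a 2.3-fold higher number from compound 2 to compound 4 (0.36 log units; beyond the scatter) as the first step in the series to leave it, though only modestly. Within the data shown here, compound 2 and compound 4 thus mark the two ends of the series as the only pair set apart, and the other compounds do not separate from their neighbours. Among these compounds, the first direct reading of the group on the amine nitrogen, 1,3-benzothiazol-2-yl in place of 1,3-benzoxazol-2-yl with tert-butoxy held fixed, gives a 1.7-fold higher number from compound 1 to compound 4 (0.22 log units; within the scatter) and shows no separable effect of that exchange. No supporting data bear on why these steps have this size.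

Still open, going by these compounds, is whether an amine or a carboxylic acid on this aromatic carbon would give a step clearly beyond the scatter, rather than one at its edge. Also open, on these data alone, is whether a longer chain in the shared core would shift the numbers at all, given how closely the four compounds sit.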